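Methyl on the Imidazole Carbon: a Second Look

The source may hold more compounds than are shown below. What is called first, only, known or untested is meant among the compounds shown, and "the series" means these compounds.

Measured so far:
compound 1, `CC(C#CCn1ccnc1)N1CCCC1=O`: > 100 mg/kg
compound 2, `Cc1cncn1CC#CC(C)N1CCCC1=O`: > 100 mg/kg
compound 3, `Cn1ccn(CC#CCn2ccnc2)c1=O`: 4.4 mg/kg

The three measured compounds were tested in a functional assay on the whole organism for agonist activity, with Mus musculus as the target; on this read-out higher numbers stand for an effect only at larger amounts of compound and lower numbers for an effect already at smaller amounts. Compound 1 gives a limit of the assay, > 100 mg/kg, and not a number. Compound 2 likewise gives only a limit, > 100 mg/kg. Among the measured compounds shown here, compound 3 is the one compound with a read number, 4.4 mg/kg. The change from compound 1 to compound 2 is methyl in place of hydrogen on an aromatic carbon. Its step is a step that the two limits leave unreadable from compound 1 to compound 2; both values sit at the limit of > 100 mg/kg in this assay, at which 2 of the 3 values shown sit, so the size of that step cannot be read.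

Compound 4, `Cc1cncn1CC#CCn1ccn(C)c1=O`, has not yet been measured. It stands to compound 3 as compound 2 stands to compound 1: the change is methyl in place of hydrogen on an aromatic carbon, the same kind of change as that from compound 1 to compound 2. The difference between the core of compound 3 and the core of compound 1 is not broken down here.

Since the earlier step left no readable size, the expectation for compound 4 rests on compound 3 alone, with its value of 4.4 mg/kg, and the step from compound 3 to compound 4 is expected to be a 1.8-fold higher number from compound 3 to compound 4 (0.26 log units; within the scatter), small in either direction. Compound 4 is therefore estimated at 8 mg/kg in this assay, with a range from 2 mg/kg to 40 mg/kg.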

Compound 4, dose for half-maximal effect: > 100 mg/kg
Compound 4 gave a limit, no number; the forecaster's own chance of this, stated with the estimate: 15%; middle value at least 12-fold (1.09 log units) from the limit.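

In this assay, methyl in place of hydrogen on an aromatic carbon, next to the ring atom that bears a large group, brings an at least 22-fold higher number from compound 3 to compound 4 (1.35 log units; beyond the scatter), so on this core the small change has a large result and the effect is no longer seen at the amounts where it was read before. On these data alone, compound 4 gives > 100 mg/kg, which is a limit of the assay and not a number, so the step has a lower bound and its full size stays unknown. The same change from compound 1 to compound 2 cannot be read, so the compounds shown do not tell whether the change acts alike on the two cores, and they show a large step on one core only: the limit of > 100 mg/kg in this assay, at which 3 of the 4 values shown sit.

The compounds shown leave open whether the result belongs to methyl itself or would follow any group at this place, such as a fluorine atom, a chlorine atom or an ethyl group. They also leave open how a group of another kind would behave here, for instance a hydroxymethyl group or an amine on the same aromatic carbon of the core of compound 3.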